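From decyl to benzyl on the shared core

The compounds below may be only part of what the source reports. "The series", "measured", "known", "first", "only" and "open" are said of these compounds alone.

Measured in a functional assay on brain (Rattus norvegicus, strain Wistar) for inhibition (on this read-out lower numbers stand for stronger inhibition and higher numbers for weaker inhibition), the three compounds read:
compound 1 `CCCCOc1ccc(-c2c(C)[nH]c(=O)n2C2CCCCC2)cc1` gives 13900 nM
compound 2 `CCCCCOc1ccc(-c2c(C)[nH]c(=O)n2C2CCCCC2)cc1` gives 9100 nM
compound 3 `CCCCCCCCCCOc1ccc(-c2c(C)[nH]c(=O)n2C2CCCCC2)cc1` gives 10500 nM

Compound 3 at 10500 nM lies within the scatter of both other compounds, so the three stand level and show no order. The next compound, compound 4 `Cc1[nH]c(=O)n(C2CCCCC2)c1-c1ccc(OCc2ccccc2)cc1`, keeps the shared core. The change is phenyl in place of nonyl on a saturated chain carbon bound to an oxygen on an aromatic ring and, cut one bond further out, it reads decyl to benzyl.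

Going by the values given here, three measured steps bear on it: a 1.5-fold lower number from compound 1 to compound 2 (0.18 log units; within the scatter) and a 1.3-fold lower number from compound 1 to compound 3 (0.12 log units; within the scatter) and also a 1.2-fold higher number from compound 2 to compound 3 (0.06 log units; within the scatter) are all small and stay within the scatter. Among the compounds with values here, all three compare chains only, so the data hold no direct precedent for phenyl in place of nonyl, and the range must stay wide. No step beyond the scatter is therefore expected in this assay in either direction. The expected step is a 1.1-fold lower number from compound 3 to compound 4 (0.04 log units; within the scatter) and remains an estimate. Compound 4 is estimated at 9500 nM with an expected range of 3500 nM to 25000 nM in this measurement.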

Compound 4, half-maximal inhibitory concentration: 8300 nM
The estimate for compound 4 lay 1.1-fold (0.06 log units) above the measured number, within the range that was stated.
By their numbers in this assay, from the lowest: compounds 4, 2, 3 and 1 (each within the scatter of the next).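

In this assay the first ring at this place, phenyl on a saturated chain carbon bound to an oxygen on an aromatic ring, stays within the scatter of all three chains: the steps are a 1.3-fold lower number from compound 3 to compound 4 (0.10 log units; within the scatter) and a 1.1-fold lower number from compound 2 to compound 4 (0.04 log units; within the scatter) and also a 1.7-fold lower number from compound 1 to compound 4 (0.22 log units; within the scatter). The earlier compounds shown here compared chains only, whereas compound 4 shows that an aromatic ring can enter here without a step beyond the scatter, so the four compounds stand level and show no order. Nothing in the data offers an explanation for this level reading.

On these data alone, whether any group at this place can move the number beyond the scatter stays open. An amine or a carboxylic acid in place of the phenyl would test this.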